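From Compound 1 to Compound 3: One Linker Exchanged

The compounds below may be only part of what the source reports. "The series", "measured", "known", "first", "only" and "open" are said of these compounds alone.

Compound 1 `CN(C)C(=O)c1cc2cnc(Nc3ccc(S(=O)(=O)NCCCCN=C=S)cc3)nc2n1C1CCCC1` was tested in a functional assay on A549 cells (Homo sapiens) for inhibition, read by CCK-8 assay, with a stated time of 72 h, tested at 1 uM (a lower number here means a weaker effect, a higher number a stronger effect of the compound at the concentration tested), and gives 39.4%, the lower of the two measured values. Compound 2 `CN(C)C(=O)c1cc2cnc(Nc3ccc(S(=O)(=O)NCCCCCCN=C=S)cc3)nc2n1C1CCCC1` gives 49.5%, and the step of a number 10.1 percentage points higher from compound 1 to compound 2 (beyond the scatter) comes from a longer chain, not from a change at the ring. Compound 3 `CN(C)C(=O)c1cc2cnc(Nc3ccc(C(=O)NCCCCN=C=S)cc3)nc2n1C1CCCC1` is not yet measured; it differs from compound 1 by a group of 10 heavy atoms (6 carbon, 2 nitrogen, 1 oxygen, 1 sulfur; no ring) in place of a group of 11 heavy atoms (5 carbon, 2 nitrogen, 2 oxygen, 2 sulfur; no ring), on an aromatic carbon, para to a large group. Among the measured compounds shown here, no measured step covers such an exchange, so there is no guide; the expected step is a number 1.4 percentage points lower from compound 1 to compound 3 (within the scatter), within the scatter. Compound 3 is therefore estimated at 38%, between 18% and 58%.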

Compound 3, a percentage reported as inhibition, at one concentration (the size of the read-out at that concentration, not a potency): 30.2%
For compound 3 the middle estimate is 7.8 percentage points above the measured one; measured number inside the range.
By their numbers in this assay, from the lowest: compounds 3 and 1 (each within the scatter of the next); then compound 2.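

Exchanging the sulfonamide for an amide on this aromatic carbon, para to a large group, gives a number 9.2 percentage points lower from compound 1 to compound 3 (within the scatter) in this assay. At this chain length, then, the linking group can be exchanged without a difference that stands clear of the usual scatter, whereas the earlier step came from the chain. No measurement at hand explains this result.

Going by these compounds, whether the amide behaves the same with the longer chain of compound 2 remains open. So does the outcome with a urea or a plain amine at this aromatic carbon.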